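Expected Loss When Hydroxymethyl Replaces Sec-Butyl

The source may hold more compounds than are shown below. What is called first, only, known or untested is meant among the compounds shown, and "the series" means these compounds.

Measured in an assay on HL-60 cells for inhibition of E-selectin (Homo sapiens), tested at 50 mM; a higher number here means more inhibition at the concentration tested (going by the name of the read-out), a lower number less inhibition:
compound 1 `C[C@H](NC(=O)[C@]1(O)C[C@@H](O)[C@@H](O)[C@H](O)C1)C(=O)O` gives 30%.
Compound 2 `CCC(C)[C@H](NC(=O)[C@]1(O)C[C@@H](O)[C@@H](O)[C@H](O)C1)C(=O)O` gives 44%.

Going by the values given here, compound 2 holds the higher of the two numbers, the single measured step being a number 14 percentage points higher from compound 1 to compound 2 (beyond the scatter). Compound 3 `O=C(O)[C@H](CO)NC(=O)[C@]1(O)C[C@@H](O)[C@@H](O)[C@H](O)C1` differs from compound 2 by hydroxymethyl in place of sec-butyl on a saturated chain carbon bound to an amide-type nitrogen and a carbonyl carbon. Among the compounds with values here, only that one step bears on this change: enlarging methyl to sec-butyl gave a modest gain, so removing sec-butyl in favour of hydroxymethyl is expected to give that gain back, roughly returning to the level of compound 1. Compound 3 is therefore estimated at 30%, between 15% and 45%, an expected step of a number 14 percentage points lower from compound 2 to compound 3 (beyond the scatter) in this assay.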

Compound 3, a percentage reported as inhibition, at one concentration (the size of the read-out at that concentration, not a potency): 46%
The estimate for compound 3 lay 16 percentage points below the measured number; the measured number lies above the stated range.
By their numbers in this assay, from the lowest: compound 1; then compounds 2 and 3 (each within the scatter of the next).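

In this assay, hydroxymethyl in place of sec-butyl gives a number 2 percentage points higher from compound 2 to compound 3 (within the scatter) and so loses nothing that can be told from scatter, while hydroxy in place of hydrogen gives a number 16 percentage points higher from compound 1 to compound 3 (beyond the scatter) as a clear gain. The gain over compound 1 therefore does not depend on a larger all-carbon group, since the smaller, oxygen-bearing hydroxymethyl serves as well as sec-butyl here. Nothing available explains why these two different groups give such similar numbers. As far as these compounds go, whether an amine, a carboxylic acid or a longer chain at this place would match them remains open.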